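The source may hold more compounds than are shown below. What is called first, only, known or untested is meant among the compounds shown, and "the series" means these compounds.

In a functional assay on HeLa cells (Homo sapiens) for cytotoxicity, read by MTT assay (a lower number here means a stronger inhibitor, a higher number a weaker inhibitor), the three measured compounds stand as follows:
compound 1, `CC(C)=CC[C@@H](OC[C@H](C)O)C1=CC(=O)c2c(O)ccc(O)c2C1=O`: 40300 nM
compound 2, `CC(C)=CC[C@@H](OC(=O)C1CCOC1)C1=CC(=O)c2c(O)ccc(O)c2C1=O`: 73500 nM
compound 3, `CC(=O)OC(C)CO[C@H](CC=C(C)C)C1=CC(=O)c2c(O)ccc(O)c2C1=O`: 40100 nM

Compound 3 sits at the low end of these three numbers, yet a 1.0-fold lower number from compound 1 to compound 3 (0.00 log units; within the scatter) and a 1.8-fold lower number from compound 2 to compound 3 (0.26 log units; within the scatter) keep it within the scatter of both neighbours. Compound 4, `CCC(CO[C@H](CC=C(C)C)C1=CC(=O)c2c(O)ccc(O)c2C1=O)OC`, differs from compound 3 in one place: 1-methoxypropyl in place of 1-acetoxyethyl on a saturated chain carbon bound to an oxygen on a saturated carbon. The step of a 1.0-fold lower number from compound 1 to compound 3 (0.00 log units; within the scatter), a change at the same saturated chain carbon, bears most on this move, and it stayed within the scatter. Among the compounds with values here, no measured pair shows an ether taking the place of an ester at that site, so the expected step of a 1.0-fold lower number from compound 3 to compound 4 (0.00 log units; within the scatter) is none beyond the scatter, in either direction. Compound 4 is thus estimated at 40000 nM, with a range from 20000 nM to 80000 nM.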

Compound 4, half-maximal inhibitory concentration: 63500 nM
Compound 4: the middle estimate sits 1.6-fold (0.20 log units) below what was measured, within the range that was stated.
By their numbers in this assay, from the lowest: compounds 3, 1, 4 and 2 (each within the scatter of the next).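

At this saturated chain carbon an ether now stands alongside the ester and the alcohol: in this assay, 1-methoxypropyl in place of 1-acetoxyethyl gives a 1.6-fold higher number from compound 3 to compound 4 (0.20 log units; within the scatter), and in place of 1-hydroxyethyl gives a 1.6-fold higher number from compound 1 to compound 4 (0.20 log units; within the scatter). On the oxygen, 2-methoxybutyl in place of (oxolan-3-yl)carbonyl gives a 1.2-fold lower number from compound 2 to compound 4 (0.06 log units; within the scatter). All four compounds therefore remain within the scatter along these steps, and no measurement here offers an explanation. Going by these compounds, whether an amine or a carboxylic acid at this place would move the number beyond the scatter remains open.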